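Phenyl for Thiophen-2-yl: an Expected Small Step

A few compounds are considered here, and "the series" means these few. Any claim that something is new, unique, unknown or untested is made for them only; others in the source may bear on it.

Going by the values given here, compound 2 `Oc1cccc(-c2cc(-c3cccc(Cl)c3)nc(-c3cccs3)c2)c1` is the only compound here with a number: in a functional assay on HCT-15 cells (Homo sapiens) for cytotoxicity, read by CCK-8 assay and cell counting, with a stated time of 2 days (on this read-out lower numbers stand for stronger inhibition and higher numbers for weaker inhibition), compound 2 gives 2610 nM. Compound 1 `Oc1cccc(-c2cc(-c3ccncc3)nc(-c3cccc(Cl)c3)c2)c1` was run in this assay but compound 1 gives only "not determined" (no result reported), so compound 2 stands alone on the numbers shown and cannot be ranked against anything. Compound 3 `Oc1cccc(-c2cc(-c3ccccc3)nc(-c3cccc(Cl)c3)c2)c1` has not yet been measured in this assay. It differs from compound 2 in one place: phenyl in place of thiophen-2-yl on an aromatic carbon of the six-membered aromatic ring with one nitrogen, next to the ring nitrogen. Among the compounds with values here, no step between two measured compounds is available to gauge such an exchange, so its size in this assay cannot be read from the data. The step is expected to stay within the scatter, in either direction, with a 1.0-fold lower number from compound 2 to compound 3 (0.02 log units; within the scatter). Compound 3 is therefore estimated at 2500 nM, within a range from 900 nM to 7000 nM.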

Compound 3, half-maximal inhibitory concentration: 2550 nM
Estimate against measurement, compound 3: 1.0-fold (0.01 log units) below, within the range that was stated.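

Putting phenyl in place of thiophen-2-yl on the aromatic carbon next to the ring nitrogen gives a 1.0-fold lower number from compound 2 to compound 3 (0.01 log units; within the scatter) in this assay. Going by these compounds alone, this is the first measured step at this position, and it shows that the five-membered aromatic ring with its sulfur and the six-membered aromatic ring of carbon only are not told apart here, since the exchange stays within the scatter. Nothing available bears on why the two groups read alike.

From the compounds shown here alone, compound 1 gives "not determined" (no result reported), so steps involving it cannot be read, and the effect of a ring nitrogen in this group stays unknown. The compounds shown also leave open whether a group of a different kind at this position, such as an amine, a carboxylic acid or a longer alkyl chain, would stay as close to compound 3.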